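A few compounds are considered here, and "the series" means these few. Any claim that something is new, unique, unknown or untested is made for them only; others in the source may bear on it.

Three compounds sharing one core have so far been measured in a physicochemical assay for solubility; a lower number here means a less soluble compound, a higher number a more soluble compound:

Compound 1 `O=C(c1cccc(Cl)c1)N1CCC(NS(=O)(=O)c2cc(S(=O)(=O)c3ccccc3)ccc2C(F)(F)F)CC1` gives 6300 nM.
Compound 2 `O=C(c1ccc(Cl)cc1)N1CCC(NS(=O)(=O)c2cc(S(=O)(=O)c3ccccc3)ccc2C(F)(F)F)CC1` gives 3100 nM.
Compound 3 `O=C(c1ccc(C(F)(F)F)cc1)N1CCC(NS(=O)(=O)c2cc(S(=O)(=O)c3ccccc3)ccc2C(F)(F)F)CC1` gives 6300 nM.

Compound 2 stands at the lowest of the three numbers: the step of a 2.0-fold lower number from compound 1 to compound 2 (0.31 log units; beyond the scatter) is modest, and the step of a 2.0-fold higher number from compound 2 to compound 3 (0.31 log units; beyond the scatter) is modest as well, while compound 1 and compound 3 show the same number at the digits given.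

The unmeasured compound 4 `O=C(c1ccccn1)N1CCC(NS(=O)(=O)c2cc(S(=O)(=O)c3ccccc3)ccc2C(F)(F)F)CC1` is reached from compound 2 by one change: pyridin-2-yl in place of 4-chlorophenyl on a carbonyl carbon. The measured steps that bear on it are a 2.0-fold lower number from compound 1 to compound 2 (0.31 log units; beyond the scatter) and a 2.0-fold higher number from compound 2 to compound 3 (0.31 log units; beyond the scatter), both modest and in this assay. Each of those steps, however, only moves a substituent on a ring of carbon only or exchanges one such substituent for another; none of them replaces the whole ring by a ring with a hetero atom that carries a hydrogen-bond acceptor. They therefore fix the scale of what has been seen but not the direction of the present change.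

The expectation for compound 4 is a step upward, estimated as a 3.2-fold higher number from compound 2 to compound 4 (0.51 log units; beyond the scatter). Compound 4 is thus estimated at 10000 nM, with a range from 4000 nM to 25000 nM.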

Compound 4, solubility: 100000 nM
Compound 4: middle estimate off by 10-fold (1.00 log units), on the low side; the whole stated range lies below it.
By their numbers in this assay, from the lowest: compound 2; then compounds 1 and 3 (each within the scatter of the next); then compound 4.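

In this assay, among the compounds shown here, the ring on the carbonyl carbon proves to matter far more than the earlier compounds showed, with pyridin-2-yl in place of 4-chlorophenyl giving a 32-fold higher number from compound 2 to compound 4 (1.51 log units; beyond the scatter) as a large step. The other two carbon-only rings give the same picture, with pyridin-2-yl in place of 4-(trifluoromethyl)phenyl giving a 16-fold higher number from compound 3 to compound 4 (1.20 log units; beyond the scatter) and pyridin-2-yl in place of 3-chlorophenyl giving a 16-fold higher number from compound 1 to compound 4 (1.20 log units; beyond the scatter) as further large steps, so among these four compounds exchanging the whole ring outweighs the modest or unseen steps from moving or exchanging a substituent on it. No measurement here separates the part played by the ring nitrogen from that of the loss of the substituent, and nothing available explains the size of the step.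

The compounds shown leave open whether a carbon-only ring carrying an amine or a carboxylic acid on the same carbonyl carbon would reach the number of compound 4. They also leave open whether a substituent such as chloro or trifluoromethyl, placed on the pyridin-2-yl ring, would keep that number or bring it back toward those of the other three compounds.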